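The source may report more compounds than this note shows. Statements on the series, on what has been measured and on what is new or still open speak of the compounds shown alone.

Measured compounds:
compound 1 `Cc1c(Nc2nc(N)c3c(C#N)c(N4CCC[C@H]4C)n(C)c3n2)cnn1C` — 310 nM
compound 2 `Cc1nn(C2CCOC2)cc1Nc1nc(N)c2c(C#N)c(N3CCC[C@H]3C)n(C)c2n1` — 140 nM; 260 nM (2 entries)
compound 3 `C[C@@H]1CCCN1c1c(C#N)c2c(N)nc(Nc3cn(C)nc3Cl)nc2n1C` — 190 nM

In an assay on HEK293 cells for inhibition of Leucine-rich repeat serine/threonine-protein kinase 2 (Homo sapiens), with a stated time of 48 h (on this read-out higher numbers stand for weaker inhibition and lower numbers for stronger inhibition), compound 1 gives the highest of the two single numbers recorded. Its nearest neighbour is compound 3, and the step of a 1.6-fold lower number from compound 1 to compound 3 (0.21 log units; within the scatter) lies within the scatter, so the two cannot be ordered. Among the measured compounds shown here, compound 2 has repeated entries the several entries of compound 2 in this assay, 140 nM; 260 nM (2 entries) that spread across the same region as compounds 1 and 3; no single step to compound 2 is counted, and its values merely show that a ring on the pyrazole nitrogen leaves the number in the same range.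

Compound 4 `Cc1c(Nc2nc(N)c3c(C#N)c(N4CCC[C@H]4C)n(C)c3n2)cnn1C1COC1` has not yet been measured. It differs from compound 1 by oxetan-3-yl in place of methyl on an aromatic nitrogen. For the measured compounds named here, the only measured steps are the one from compound 1 to compound 3, which is within the scatter, and the spread of compound 2, whose ring on the same nitrogen gives numbers of the same order as compound 1. On this basis no step beyond the scatter is expected in this assay, at most a slight move toward lower numbers.

The estimate for compound 4 is 200 nM, expected between 90 nM and 450 nM, which means a step of a 1.6-fold lower number from compound 1 to compound 4 (0.19 log units; within the scatter).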

Compound 4, half-maximal inhibitory concentration: 300 nM
Estimate against measurement, compound 4: 1.5-fold (0.18 log units) below, within the range that was stated.
By their numbers in this assay, from the lowest: compounds 3, 4 and 1 (each within the scatter of the next).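

In this assay, among the compounds shown here, the change to oxetan-3-yl in place of methyl on the aromatic nitrogen gives a 1.0-fold lower number from compound 1 to compound 4 (0.01 log units; within the scatter) and so adds a second direct reading at this position: a larger group with a four-membered non-aromatic ring and a hydrogen-bond acceptor produces no step that can be read. The wider exchange, 5-methyl-1-(oxetan-3-yl)-1H-pyrazol-4-yl in place of 3-chloro-1-methyl-1H-pyrazol-4-yl, gives a 1.6-fold higher number from compound 3 to compound 4 (0.20 log units; within the scatter) and likewise separates nothing, so the three single-value compounds remain one group in this assay. Neither step is wider than the spread within one compound, seen in: the several entries of compound 2 in this assay, 140 nM; 260 nM (2 entries)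

The compounds shown leave open whether a different group on this nitrogen, such as a piperidine ring carrying an amine or a longer chain ending in a carboxylic acid, would produce a step beyond the scatter. They also leave open whether oxetan-3-yl would give the same reading if a cyclopropyl group replaced the methyl on the neighbouring ring atom.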